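The source may report more compounds than this note shows. Statements on the series, on what has been measured and on what is new or still open speak of the compounds shown alone.

Working notes on the series in a functional assay on MGC-803 cells (Homo sapiens) for cytotoxicity, read by MTT assay, with a stated time of 2 days; a higher number here means a weaker inhibitor, a lower number a stronger inhibitor. Compound 1 `O=[N+]([O-])c1ccc2c(c1)/C(=N\O)C(c1c[nH]c3ccc([N+](=O)[O-])cc13)=N2` gives 10800 nM. Compound 2 `Cc1ccc(CO/N=C2/C(c3c[nH]c4ccccc34)=Nc3ccccc32)cc1` gives 22800 nM in this assay. Compound 3 `Fc1ccc(CO/N=C2/C(c3c[nH]c4ccccc34)=Nc3ccccc32)cc1` gives 33000 nM in this assay, the highest of the three numbers; the gap to compound 2 is within the scatter, the gap to compound 1 beyond it. Among the compounds with values here, the only measured step on the benzyl ring, a 1.4-fold higher number from compound 2 to compound 3 (0.16 log units; within the scatter), stays within the scatter.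

Compound 4 `Fc1ccc(CO/N=C2/C(c3c[nH]c4ccccc34)=Nc3ccccc32)c(Cl)c1` differs from compound 3 by chloro in place of hydrogen on an aromatic carbon. Within the data shown here, no measured step swaps a hydrogen for a chloro, so the one step that bears on this ring is the swap of methyl for fluoro, and that step produced no change beyond the scatter. The expectation for compound 4 in this assay is therefore a step of about a 1.1-fold lower number from compound 3 to compound 4 (0.04 log units; within the scatter), which is no step beyond the scatter. Compound 4 is estimated at 30000 nM, with a range from 12000 nM to 80000 nM.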

Compound 4, half-maximal inhibitory concentration: 18500 nM
The estimate for compound 4 lay 1.6-fold (0.21 log units) above the measured number, and the stated range covers the measured number.
By their numbers in this assay, from the lowest: compounds 1, 4, 2 and 3 (each within the scatter of the next, the first and the last beyond it).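

In this assay, the series now has a measured step for replacing a hydrogen on the benzyl ring: chloro on an aromatic carbon, ortho to a large group and meta to the fluoro group, gives a 1.8-fold lower number from compound 3 to compound 4 (0.25 log units; within the scatter), so this change does not move the number beyond the scatter. The larger swap of 4-methylphenyl for 2-chloro-4-fluorophenyl gives a 1.2-fold lower number from compound 2 to compound 4 (0.09 log units; within the scatter), which shows that the two ring changes taken together also stay within the scatter. No evidence on the origin of these small steps accompanies the series.

As far as these compounds go, whether an amine or a carboxylic acid on this ring would give a step beyond the scatter remains open, as does whether chloro would behave alike elsewhere on the ring. From the compounds shown here alone, compound 1 differs from the other compounds in more than one place, so the source of its gap to compound 3 also remains open.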